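The source may hold more compounds than are shown below. What is called first, only, known or untested is meant among the compounds shown, and "the series" means these compounds.

The series shares one core, seen in compound 1 `CC[C@@H]1/C=C(\C)C[C@H](C)C[C@H](OC)[C@H]2O[C@@](O)(C(=O)C(=O)N3CCCC[C@H]3C(=O)O[C@H](/C(C)=C/[C@@H]3CC[C@@H](Oc4ccccc4)[C@H](OC)C3)[C@H](C)[C@@H](O)CC1=O)[C@H](C)C[C@@H]2OC`. In a functional assay on cells for inhibition, with Murine T-cell line (Mus musculus) as the target (a lower number here means a stronger inhibitor, a higher number a weaker inhibitor), compound 1 gives 5.4 nM, the highest number among the three measured compounds. Compound 3 `CC[C@@H]1/C=C(\C)C[C@H](C)C[C@H](OC)[C@H]2O[C@@](O)(C(=O)C(=O)N3CCCC[C@H]3C(=O)O[C@H](/C(C)=C/[C@@H]3CC[C@@H](Oc4ccccc4)[C@H](O)C3)[C@H](C)[C@@H](O)CC1=O)[C@H](C)C[C@@H]2OC` gives 5.2 nM in this assay; the step of a 1.0-fold lower number from compound 1 to compound 3 (0.02 log units; within the scatter) lies within the scatter. Compound 2 `CC[C@@H]1/C=C(\C)C[C@H](C)C[C@H](OC)[C@H]2O[C@@](O)(C(=O)C(=O)N3CCCC[C@H]3C(=O)O[C@H](/C(C)=C/[C@@H]3CC[C@@H](O)[C@H](Oc4ccc(OC)cc4)C3)[C@H](C)[C@@H](O)CC1=O)[C@H](C)C[C@@H]2OC` gives 0.9 nM in this assay, a lower number than compound 1, but compound 2 differs from compound 1 in more than one place, so no single step can be read from this pair.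

Compound 4 `CC[C@@H]1/C=C(\C)C[C@H](C)C[C@H](OC)[C@H]2O[C@@](O)(C(=O)C(=O)N3CCCC[C@H]3C(=O)O[C@H](/C(C)=C/[C@@H]3CC[C@@H](Oc4cccc(OC)c4)[C@H](OC)C3)[C@H](C)[C@@H](O)CC1=O)[C@H](C)C[C@@H]2OC` is not yet measured. It differs from compound 1 by methoxy in place of hydrogen on an aromatic carbon, the methoxy entering on an aromatic carbon of the six-membered aromatic ring of carbon only, meta to a large group. Among the compounds with values here, no measured step alters this ring in the same way: the only measured single step, a 1.0-fold lower number from compound 1 to compound 3 (0.02 log units; within the scatter), concerns hydrogen in place of methyl on an oxygen on a saturated carbon and stayed within the scatter. Compound 2 also carries a methoxy on an aromatic ring, but together with a second change, so its value gives no clean guide. For compound 4 the step of a 1.2-fold lower number from compound 1 to compound 4 (0.08 log units; within the scatter) is therefore expected to remain within the scatter, with no clear direction. Compound 4 is estimated at 4.5 nM, with a range from 1.5 nM to 13 nM.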

Compound 4, half-maximal inhibitory concentration: 3.4 nM
The estimate for compound 4 lay 1.3-fold (0.12 log units) above the measured number, within the range that was stated.
By their numbers in this assay, from the lowest: compound 2; then compounds 4, 3 and 1 (each within the scatter of the next).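

On the phenoxy group of compound 1, the aromatic ring now has a clean single-place read: in this assay the change from phenoxy to 3-methoxyphenoxy gives a 1.6-fold lower number from compound 1 to compound 4 (0.20 log units; within the scatter) and so shows no change that can be told from the scatter. Within the data shown here, this aromatic carbon therefore accepts a methoxy in place of hydrogen with the number staying in the same low nanomolar region, something the earlier compounds could not show, since compound 2 carries its aromatic methoxy together with a second change. The other single-place step in the series, a 1.0-fold lower number from compound 1 to compound 3 (0.02 log units; within the scatter), also stays within the scatter, and nothing available bears on the reason for either result.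

On these data alone, a single substituent at one place on this ring says little about the ring as a whole, so an amine, a carboxylic acid or a longer chain such as ethoxy on the same aromatic carbon remains open. Also open, as far as these compounds go, is whether the 3-methoxyphenoxy group would behave in the same way alongside the free hydroxyl of compound 3.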